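Hydroxylated amide extension on a chemokine receptor antagonist

This account rests on a few compounds, and the source may have more. Where it says the series, first, only, none or still open, it means among the compounds named here.

Measured compounds:
- compound 1, `CC(=O)NCc1cccc(Cn2nc(NS(=O)(=O)c3ccc(Cl)s3)c3c(C(F)F)cccc32)c1`: 7940 nM
- compound 2, `COc1cc(F)cc2c1c(NS(=O)(=O)c1ccc(Cl)s1)nn2Cc1cccc(CNC(C)=O)c1`: 1000 nM

Of the compounds shown here, two have been tested in an assay on isolated protein (blood) for antagonist activity at C-C chemokine receptor type 4 (Homo sapiens), read by flow cytometry, with a stated time of 30 min; a lower number here means tighter binding, a higher number weaker binding. Compound 1, `CC(=O)NCc1cccc(Cn2nc(NS(=O)(=O)c3ccc(Cl)s3)c3c(C(F)F)cccc32)c1`, gives 7940 nM in this assay. Compound 2, `COc1cc(F)cc2c1c(NS(=O)(=O)c1ccc(Cl)s1)nn2Cc1cccc(CNC(C)=O)c1`, gives 1000 nM in this assay, the lower of the two numbers, and the gap to compound 1 lies beyond the usual scatter. The two compounds differ in several places at once, so the numbers alone do not say which change is responsible.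

The next compound, compound 3, `COc1cc(F)cc2c1c(NS(=O)(=O)c1ccc(Cl)s1)nn2Cc1cccc(CNC(=O)C(C)(C)O)c1`, keeps the whole of compound 2 and alters only the amide group on the side chain: 1-hydroxy-1-methylethyl in place of methyl on a carbonyl carbon. This exchange leaves the ring system and the sulfonamide part untouched.

Among the measured compounds shown here, no measured pair in this set shows the effect of such an exchange, so the expectation rests on the change being small and peripheral. The step of a 1.3-fold lower number from compound 2 to compound 3 (0.10 log units; within the scatter) is expected to stay within the scatter, with no clear direction. Compound 3 is therefore estimated to give about 800 nM in this assay, within a range from 250 nM to 2500 nM.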

Compound 3, dissociation constant in the C-C chemokine receptor type 4 assay: 631 nM
The estimate for compound 3 lay 1.3-fold (0.10 log units) above the measured number; the measured number falls inside the stated range.
By their numbers in the C-C chemokine receptor type 4 assay, from the lowest: compounds 3 and 2 (each within the scatter of the next); then compound 1.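

In the C-C chemokine receptor type 4 assay compound 2 gives 1000 nM and compound 3 gives 631 nM, and the exchange of methyl for 1-hydroxy-1-methylethyl on a carbonyl carbon gives a 1.6-fold lower number from compound 2 to compound 3 (0.20 log units; within the scatter), so the two compounds cannot be told apart, even though the entering group brings 4 heavy atoms, 1 hydrogen-bond donor and 1 hydrogen-bond acceptor. Among the compounds shown here, this is the first pair here that differs in one place only, so it gives the first direct reading at this position, which compound 1 and compound 2 could not give with their several differences: at this carbonyl carbon, the larger hydroxylated group leaves the number within the scatter of the methyl compound. Nothing measured here bears on the reason for this result.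

In a physicochemical assay for acid dissociation, compound 2 is recorded as "not determined" (no result reported) and compound 3 as "not determined" (no result reported), so that comparison cannot be read. Going by these compounds, it also remains open whether the hydroxyl matters at all, which a plain 1-methylethyl group at this carbonyl carbon would test, and whether an amine, a carboxylic acid or a longer chain there would move the number beyond the scatter in either direction.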